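The source may hold more compounds than are shown below. What is called first, only, known or untested is meant among the compounds shown, and "the series" means these compounds.

Measured so far in a functional assay on HeLa S3 cells (Homo sapiens) for cytotoxicity, read by XTT assay, with a stated time of 3 days; a higher number here means a weaker inhibitor, a lower number a stronger inhibitor:
- compound 1 `OC[C@H]1O[C@@H](n2cc(F)c3c(-c4ccccc4)ncnc32)[C@H](O)[C@@H]1O`: 2600 nM
- compound 2 `OC[C@H]1O[C@@H](n2cc(F)c3c(-c4ccco4)ncnc32)[C@H](O)[C@@H]1O`: 8000 nM

Compound 1 holds the lower of these two numbers, 2600 nM, which makes it the stronger inhibitor of the pair. Compound 2 differs from it only in one ring, and the change is a 3.1-fold higher number from compound 1 to compound 2 (0.49 log units; beyond the scatter). That gap is modest but lies beyond the scatter.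

The next compound is compound 3 `OC[C@H]1O[C@@H](n2cc(F)c3c(-c4cccs4)ncnc32)[C@H](O)[C@@H]1O`, which keeps the shared core of compound 1 and changes one group: thiophen-2-yl in place of phenyl on an aromatic carbon. In short, thiophen-2-yl stands in place of phenyl on an aromatic carbon.

Going by the values given here, only one measured step bears on this swap: a 3.1-fold higher number from compound 1 to compound 2 (0.49 log units; beyond the scatter). There, furan-2-yl replaced phenyl on the same carbon. Among the compounds with values here, it is a single example, and no measured compound yet carries thiophen-2-yl, so it is a weak guide. It points towards a somewhat higher number in this assay, with a shift no larger than that one. The estimated change is a 1.3-fold higher number from compound 1 to compound 3 (0.13 log units; within the scatter), so no step beyond the scatter is expected.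

In this assay, the estimate for compound 3 is 3500 nM, with an expected range of 1000 nM to 12000 nM.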

Compound 3, half-maximal inhibitory concentration: 4300 nM
Beside the measured number, compound 3's estimate is 1.2-fold (0.09 log units) below it, within the range that was stated.
By their numbers in this assay, from the lowest: compounds 1, 3 and 2 (each within the scatter of the next, the first and the last beyond it).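

In this assay, thiophen-2-yl in place of phenyl on this aromatic carbon gives a 1.7-fold higher number from compound 1 to compound 3 (0.22 log units; within the scatter) and is therefore not a clear change. Thiophen-2-yl in place of furan-2-yl gives a 1.9-fold lower number from compound 2 to compound 3 (0.27 log units; within the scatter) and is likewise not a clear change, so compound 3 cannot be told apart from either neighbour, even though the step between those two neighbours lies beyond the scatter. This shows that a five-membered aromatic ring with one hetero atom in place of phenyl need not produce a step beyond the scatter, so the earlier step from phenyl to furan-2-yl does not hold for every such ring, and no measurement here explains the differences.

All three compounds carry an aromatic ring at this position, so the compounds shown leave open what a non-aromatic group there, such as an amine or a longer alkyl chain, would do to the number. They also leave open whether a six-membered ring with a nitrogen, such as a pyridine, would behave like phenyl or like the five-membered rings.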